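Changing the amide substituent: working notes

The source may hold more compounds than are shown below. What is called first, only, known or untested is meant among the compounds shown, and "the series" means these compounds.

Measured so far in a functional assay on CLL cells (Homo sapiens) for cytotoxicity, read by MTT assay, with a stated time of 48 h (a higher number here means that more compound is needed for the effect, a lower number that less compound is needed), for this series:
- compound 1 (`C=C(CC)C(=O)c1ccc(OCC(=O)Nc2ccc(C(=O)O)cc2)c(Cl)c1Cl`) gives 5000 nM as its value
- compound 2 (`C=C(CC)C(=O)c1ccc(OCC(=O)Nc2ccc(O)cc2)c(Cl)c1Cl`) gives 6400 nM as its value
- compound 3 (`C=C(CC)C(=O)c1ccc(OCC(=O)NCCO)c(Cl)c1Cl`) has no value yet

Compound 2 holds the higher of the two numbers, yet at 6400 nM in this assay it sits within the scatter of compound 1. The next change is 2-hydroxyethyl in place of 4-hydroxyphenyl on an amide-type nitrogen. Going by the values given here, only one measured step bears on it, and only indirectly: a 1.3-fold higher number from compound 1 to compound 2 (0.11 log units; within the scatter) is small and swaps carboxy for hydroxy on an aromatic carbon. That step leaves the ring in place, whereas compound 3 loses it. Among the compounds with values here, no measured compound shows what removing the ring does, so the direction is poorly supported and the range has to stay wide. The estimated step is a 1.1-fold higher number from compound 2 to compound 3 (0.04 log units; within the scatter) and no shift beyond the scatter is expected. The expected value for compound 3 is 7000 nM in this assay, with an estimated range from 2500 nM to 20000 nM for the coming measurement.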

Compound 3, half-maximal effective concentration: > 25000 nM
Compound 3: only a limit was reported; the forecaster's own chance of this, stated with the estimate: 10%; middle value at least 3.5-fold (0.55 log units) away from the limit.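

In this assay compound 3 gives > 25000 nM, which is a limit of the assay and not a number. Going by these compounds alone, this amide nitrogen is therefore sensitive to the substituent it carries, and 2-hydroxyethyl in place of 4-hydroxyphenyl gives the first step beyond the scatter: an at least 3.9-fold higher number from compound 2 to compound 3 (0.59 log units; beyond the scatter), with 2-hydroxyethyl in place of 4-carboxyphenyl giving an at least 5.0-fold higher number from compound 1 to compound 3 (0.69 log units; beyond the scatter). Compound 1 and compound 2 showed only that hydroxy and carboxy on the aromatic ring are interchangeable within the scatter, whereas the new steps show that this position does not tolerate every substituent, and both are lower bounds only because compound 3 sits at the limit: the limit of > 25000 nM in this assay, at which 1 of the 3 values shown sits.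

Compound 3 differs from compound 2 both in lacking the aromatic ring and in carrying a smaller substituent, so the compounds shown do not separate these two differences, and the true size of the steps remains unknown. An unsubstituted phenyl or a benzyl group on the same nitrogen, or a longer chain ending in hydroxy, would help show whether the aromatic ring itself or the size of the substituent matters here.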